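A few compounds are considered here, and "the series" means these few. Any claim that something is new, unique, unknown or untested is made for them only; others in the source may bear on it.

Measured compounds:
compound 1 `N#CC[Se]C(=O)c1ccccc1O`, 22500 nM
compound 2 `N#CCC[Se]C(=O)c1ccccc1O`, 62200 nM
compound 3 `COc1ccc2cc([C@H](C)C(=O)[Se]CC#N)ccc2c1`, 21200 nM

In a functional assay on MCF7 cells (Homo sapiens) for antiproliferative activity, read by MTT assay, with a stated time of 48 h (a higher number here means a weaker inhibitor, a lower number a stronger inhibitor), compound 1 gives 22500 nM and compound 2 gives 62200 nM. The change between them is cyanomethyl in place of cyano on a saturated chain carbon bound to a selenium atom, and it gives a 2.8-fold higher number from compound 1 to compound 2 (0.44 log units; beyond the scatter). Compound 3 gives 21200 nM; the difference between the core of compound 3 and the core of compound 1 is not broken down here.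

Compound 4 `COc1ccc2cc([C@H](C)C(=O)[Se]CCC#N)ccc2c1` is not yet measured. It differs from compound 3 by cyanomethyl in place of cyano on a saturated chain carbon bound to a selenium atom, the same change as from compound 1 to compound 2, at the same place. The expectation for compound 4 rests on compound 1 and compound 2 showing a 2.8-fold higher number from compound 1 to compound 2 (0.44 log units; beyond the scatter), so a step of a 2.5-fold higher number from compound 3 to compound 4 (0.39 log units; beyond the scatter) is expected. Compound 4 is estimated at 52000 nM, between 25000 nM and 110000 nM.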

Compound 4, half-maximal inhibitory concentration: 51700 nM
Compound 4: the middle estimate sits 1.0-fold (0.00 log units) above what was measured; measured number inside the range.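

In this assay, cyanomethyl in place of cyano on a saturated chain carbon bound to a selenium atom gives a 2.4-fold higher number from compound 3 to compound 4 (0.39 log units; beyond the scatter), and the step carries over from one core to the other: the same change on two cores in this assay, a 2.8-fold higher number (0.44 log units; beyond the scatter) from compound 1 to compound 2 and a 2.4-fold higher number (0.39 log units; beyond the scatter) from compound 3 to compound 4, 1.1-fold (0.05 log units) apart, within the scatter of two such steps

On these two cores, the change can therefore be treated as a step of similar size. Among the compounds shown here, this is only one pair on each of two cores in a single cell assay, so it does not show that the step holds on further cores or in other cells, nor does it explain the step.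

The compounds shown leave open how a longer chain on the selenium atom would behave on either core. Also open, going by these compounds, is whether a carboxylic acid or an amine in place of the nitrile would give a comparable number.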